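A few compounds are considered here, and "the series" means these few. Any claim that something is new, unique, unknown or untested is made for them only; others in the source may bear on it.

Of the compounds shown here, two sharing one core have been measured in an assay on isolated protein for inhibition of Nitric oxide synthase, inducible (Homo sapiens), with a stated time of 30 min, tested at 1 mM; on this read-out higher numbers stand for more inhibition at the one concentration tested (going by the name of the read-out) and lower numbers for less inhibition. Compound 1 `CCCC(=O)N1CCC(c2cc(Cl)ccc2N)=N1` gives 0.29%, and compound 2 `Nc1ccc(Cl)cc1C1=NN(C(=O)C2CC2)CC1` gives 18.9%, the higher of the two numbers. Among the compounds with values here, the single step between them, cyclopropyl in place of propyl on a carbonyl carbon, gave a number 18.6 percentage points higher from compound 1 to compound 2 (beyond the scatter). Compound 3 `Nc1ccc(Cl)cc1C1=NN(C(=O)c2ccccc2)CC1` differs from compound 2 in one place: phenyl in place of cyclopropyl on a carbonyl carbon. Within the data shown here, the earlier step bears on this one only loosely: both swap the group on the same carbonyl carbon, and a modest gain came when cyclopropyl replaced propyl, but no measured pair shows what a phenyl does there. The expected step of a number 1.1 percentage points higher from compound 2 to compound 3 (within the scatter) is therefore small and uncertain, possibly none beyond the scatter, in either direction. Compound 3 is estimated at 20%, with a range from 0% to 45%.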

Compound 3, a percentage reported as inhibition, at one concentration (the size of the read-out at that concentration, not a potency): 17%
Beside the measured number, compound 3's estimate is 3 percentage points above it; the measured number falls inside the stated range.
By their numbers in this assay, from the lowest: compound 1; then compounds 3 and 2 (each within the scatter of the next).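

In this assay, replacing cyclopropyl with phenyl on this carbonyl carbon brings a six-membered aromatic ring where a three-membered non-aromatic ring stood, and the result is a number 1.9 percentage points lower from compound 2 to compound 3 (within the scatter). Phenyl in place of propyl gives a number 16.7 percentage points higher from compound 1 to compound 3 (beyond the scatter), so among these three compounds, both ring-bearing groups give higher numbers than the open propyl chain, and the two rings cannot be told apart. Nothing available explains these differences.

The compounds shown leave open whether a ring itself matters at this carbonyl carbon, something a longer chain or a branched chain such as isopropyl could help test. They also leave open how a phenyl carrying a substituent, or a pyridine ring, would compare with the plain phenyl.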